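Replacing Thiophen-2-yl with Phenyl on the Shared Core

This account rests on a few compounds, and the source may have more. Where it says the series, first, only, none or still open, it means among the compounds named here.

Compound 1 `CC1CCCc2c1nc(N)c(C#N)c2-c1cccn1C`: > 100000 nM
Compound 2 `Cn1cccc1-c1cc(-c2cccs2)[nH]c(=O)c1C#N`: > 100000 nM
Compound 3 `CC1CCCc2c1[nH]c(=O)c(C#N)c2-c1cccn1C`: > 100000 nM

These values come from a functional assay on MOLT-4 cells (Homo sapiens) for inhibition, read by sulforhodamine B assay, with a stated time of 48 h; on this read-out higher numbers stand for weaker inhibition of growth and lower numbers for stronger inhibition of growth. Each of them is a limit of the assay rather than a number, and all three sit at that same limit (the limit of > 100000 nM in this assay, at which 3 of the 3 values shown sit). Compound 2 therefore cannot be placed above or below compound 1 or compound 3; it stands, like them, at the edge of what this assay reports.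

Compound 4 `Cn1cccc1-c1cc(-c2ccccc2)[nH]c(=O)c1C#N` has not been measured yet. It differs from compound 2 by phenyl in place of thiophen-2-yl on an aromatic carbon. Among the measured compounds shown here, no measured step of this kind is available, so the expectation rests only on where compound 2 stands. For the measured compounds named here, with every value so far at the limit, no shift beyond the scatter is expected, and most likely this assay will again report only a limit. Compound 4 is estimated at 150000 nM, with a range from 40000 nM to 600000 nM, which would mean a step that the limit leaves unreadable from compound 2 to compound 4.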

Compound 4, concentration for 50% growth inhibition: 29100 nM
Compound 4: the middle estimate sits 5.2-fold (0.71 log units) above what was measured; measured number below the stated range.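

On the aromatic carbon next to the ring nitrogen, phenyl in place of thiophen-2-yl gives an at least 3.4-fold lower number from compound 2 to compound 4 (0.53 log units; beyond the scatter) in this assay. Among the compounds shown here, this position can therefore move the read-out off the limit, and compound 4 is the first compound here with a real number. The full size of the step stays unknown because compound 2 gives only a limit: the limit of > 100000 nM in this assay, at which 3 of the 4 values shown sit.

The compounds shown cannot separate the effect of the larger ring from the loss of sulfur. On these data alone, how a methyl group, an amine or a substituted phenyl would behave at this position also stays open.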